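Where the chlorine sits on the chlorophenyl group

The compounds below may be only part of what the source reports. "The series", "measured", "known", "first", "only" and "open" are said of these compounds alone.

In a functional assay on HL-60 cells (Homo sapiens) for inhibition, read by MTT assay, with a stated time of 72 h (on this read-out lower numbers stand for stronger inhibition and higher numbers for weaker inhibition), compound 1 `Cc1ccc(C)c(N2CCN(C(=O)c3oc(C)nc3-c3ccccc3Cl)CC2)c1` reaches only a limit, > 1000 nM. For the measured compounds named here, compound 2 `Cc1ccc(C)c(N2CCN(C(=O)c3oc(C)nc3-c3cccc(Cl)c3)CC2)c1` gives 345 nM, the only actual number so far. Compound 3 `Cc1ccc(C)c(N2CCN(C(=O)c3oc(C)nc3-c3ccc(Cl)cc3)CC2)c1` carries 4-chlorophenyl in place of 3-chlorophenyl on an aromatic carbon. Going by the values given here, one measured step bears on this: an at least 2.8-fold lower number from compound 1 to compound 2 (0.46 log units; beyond the scatter). It shows that such a swap can matter in this assay, but it gives no direction for this new one. The expected step of a 1.2-fold higher number from compound 2 to compound 3 (0.06 log units; within the scatter) is therefore small and probably stays within the scatter. For compound 3 the estimated value is 400 nM, with an expected range of 140 nM to 1000 nM.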

Compound 3, half-maximal inhibitory concentration: "not active" (no number reported)
No number was reported for compound 3, so the estimate cannot be set against anything.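

Compound 3 is reported only as "not active", with no number, so no step can be read between compound 2 and compound 3. Where compound 3 actually stands stays open, and the nearest reference point is: the limit of > 1000 nM in this assay, at which 1 of the 3 values shown sits.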